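The source may hold more compounds than are shown below. What is called first, only, known or untested is meant among the compounds shown, and "the series" means these compounds.

Values in a functional assay on U-87MG ATCC cells for cytotoxicity against U-87 MG (Homo sapiens), read by MTT assay, with a stated time of 72 h (on this read-out lower numbers stand for stronger inhibition and higher numbers for weaker inhibition), so far:
- compound 1 `COc1ncc(-c2ccc3nc(NC(=O)NCC(=O)N4CCCCC4)nn3c2)cc1NS(=O)(=O)c1ccc(F)cc1` gives 740 nM
- compound 2 `COc1ncc(-c2ccc3nc(NC(=O)NCCN4CCCC4)nn3c2)cc1NS(=O)(=O)c1ccc(F)cc1` gives 1120 nM
- compound 3 `COc1ncc(-c2ccc3nc(NC(=O)NCCN4CCCCC4)nn3c2)cc1NS(=O)(=O)c1ccc(F)cc1` gives 1080 nM

Compound 3 lies within the scatter of the other two values (a 1.0-fold lower number from compound 2 to compound 3 (0.02 log units; within the scatter)) and (a 1.5-fold higher number from compound 1 to compound 3 (0.16 log units; within the scatter)). Compound 4 `COc1ncc(-c2ccc3nc(NC(=O)NCCN(C)C)nn3c2)cc1NS(=O)(=O)c1ccc(F)cc1` differs from it at one place (dimethylamino in place of piperidin-1-yl on a saturated chain carbon, two bonds along the chain from an amide-type nitrogen). The closest evidence is the exchange of pyrrolidin-1-yl for piperidin-1-yl at this same place (a 1.0-fold lower number from compound 2 to compound 3 (0.02 log units; within the scatter)). The exchange at the chain carbon bound to the amide-type nitrogen also stayed small (a 1.5-fold higher number from compound 1 to compound 2 (0.18 log units; within the scatter)). Within the data shown here, no measured compound lacks a ring at this place, so the evidence is indirect. In this assay no step beyond the scatter is expected, and neither direction is favoured (a 1.0-fold higher number from compound 3 to compound 4 (0.01 log units; within the scatter)). The estimated value for compound 4 is 1100 nM (expected range 500 nM to 2400 nM).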

Compound 4, half-maximal inhibitory concentration: 980 nM
Beside the measured number, compound 4's estimate is 1.1-fold (0.05 log units) above it; the measured number falls inside the stated range.
By their numbers in this assay, from the lowest: compounds 1, 4, 3 and 2 (each within the scatter of the next).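

In this assay, dimethylamino, which has no ring, in place of piperidin-1-yl stays within the scatter (a 1.1-fold lower number from compound 3 to compound 4 (0.04 log units; within the scatter)), as it does in place of pyrrolidin-1-yl (a 1.1-fold lower number from compound 2 to compound 4 (0.06 log units; within the scatter)). A ring at this place is therefore not needed for a value in this range, which the ring-bearing compounds could not show, and the step from the (piperidin-1-yl)carbonyl compound also stays within the scatter (a 1.3-fold higher number from compound 1 to compound 4 (0.12 log units; within the scatter)). No measurement available here explains this lack of change. Still open, as far as these compounds go, is whether a primary amine, a carboxylic acid or a longer chain at this place would give a step beyond the scatter.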